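From bromo to trifluoromethyl: an expected limit

The source may report more compounds than this note shows. Statements on the series, on what has been measured and on what is new or still open speak of the compounds shown alone.

Compound 1, `O=C(Nc1ccccc1Cl)c1ccc2cccc(O)c2n1`, in an ADME assay on THP-1 cells (Homo sapiens) for cytotoxicity, read by WST assay, with a stated time of 24 h (a lower number here means a stronger inhibitor, a higher number a weaker inhibitor), gives > 30000 nM, a limit of the assay.
Compound 2, `O=C(Nc1ccccc1Br)c1ccc2cccc(O)c2n1`, in this assay gives > 30000 nM, also a limit of the assay.

Compound 2 therefore stands only at a limit, one of the two values that sit at the limit of > 30000 nM in this assay, at which 2 of the 2 values shown sit. The step from compound 1 to compound 2, a step that the two limits leave unreadable from compound 1 to compound 2, cannot be read; both of its ends are limits. Compound 3, `O=C(Nc1ccccc1C(F)(F)F)c1ccc2cccc(O)c2n1`, differs from compound 2 by trifluoromethyl in place of bromo on an aromatic carbon. With no readable step to build on, no step beyond the scatter is expected in this assay, and a further limit is the most likely outcome. Compound 3 is thus expected to give 40000 nM, within 15000 nM to 120000 nM. The estimated step is a step that the limit leaves unreadable from compound 2 to compound 3.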

Compound 3, half-maximal inhibitory concentration: > 30000 nM
Compound 3 gave a limit, no number; the forecaster's own chance of this, stated with the estimate: 85%; the middle value lies beyond the limit too.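

No step among compound 1, compound 2 and compound 3 can be read, because all three sit at the same limit: the limit of > 30000 nM in this assay, at which 3 of the 3 values shown sit.

Left open is whether chloro, bromo and trifluoromethyl differ at all in this assay, since no compound shown gives a number.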